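Methylating the Amine Nitrogen of Compound 3

A few compounds are considered here, and "the series" means these few. Any claim that something is new, unique, unknown or untested is made for them only; others in the source may bear on it.

Measured so far in an assay on CHO cells for binding affinity to Substance-P receptor (Homo sapiens); a higher number here means a weaker inhibitor, a lower number a stronger inhibitor:
compound 1 `CCCCCN(CCCCC)C(=O)N1CCN(C(=O)N(c2ccccc2)c2ccccc2)[C@H](C(=O)NCCN(C(C)C)C(C)C)C1` gives 217 nM
compound 2 `CCCCCN(CCCCC)C(=O)N1CCN(C(=O)N(c2ccccc2)c2ccccc2)[C@H](C(=O)NCCCN(CC)CC)C1` gives 41 nM
compound 3 `CCCCCN(CCCCC)C(=O)N1CCN(C(=O)N(c2ccccc2)c2ccccc2)[C@H](C(=O)NCCNCc2ccccc2OC)C1` gives 9 nM

All three share one core and differ only at the amine end of the side chain. Compound 3 stands lowest of the three numbers in this assay: the step of a 4.6-fold lower number from compound 2 to compound 3 (0.66 log units; beyond the scatter) is modest, and the step of a 24-fold lower number from compound 1 to compound 3 (1.38 log units; beyond the scatter) is large, so compound 3 is the strongest inhibitor among them. The step of a 5.3-fold lower number from compound 1 to compound 2 (0.72 log units; beyond the scatter) shows that the choice of groups on that amine nitrogen matters.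

Compound 4 `CCCCCN(CCCCC)C(=O)N1CCN(C(=O)N(c2ccccc2)c2ccccc2)[C@H](C(=O)NCCN(C)Cc2ccccc2OC)C1` differs from compound 3 by methyl in place of hydrogen on an amine nitrogen. Among the measured compounds shown here, none of the measured steps is this exact change; all three swap whole groups on the amine rather than adding a methyl. The earlier steps shown here do show that the amine end is sensitive, so a step beyond the scatter is possible, but its direction is not settled by the data. Compound 4 is therefore expected to stay near compound 3, perhaps a little weaker, with the step of a 1.7-fold higher number from compound 3 to compound 4 (0.22 log units; within the scatter). The estimate for compound 4 in this assay is 15 nM, in a range from 5 nM to 45 nM.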

Compound 4, half-maximal inhibitory concentration: 9 nM
The estimate for compound 4 lay 1.7-fold (0.22 log units) above the measured number; low and high end bracket the measured number.
By their numbers in this assay, from the lowest: compounds 3 and 4 (each within the scatter of the next); then compound 2; then compound 1.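

In this assay, a methyl can sit on the amine nitrogen of the side chain with no detectable effect, no change at the digits printed from compound 3 to compound 4 (within the scatter), so the hydrogen on that nitrogen is not needed to keep the number low. Among the compounds shown here, this also separates two features that the earlier compounds left tied together: compound 3 was the only one with a hydrogen on that nitrogen as well as the only one with a 2-methoxybenzyl group, whereas compound 4 keeps the benzyl group and loses the hydrogen, and it still holds the full lead, with a 4.6-fold lower number from compound 2 to compound 4 (0.66 log units; beyond the scatter) and a 24-fold lower number from compound 1 to compound 4 (1.38 log units; beyond the scatter). The low number therefore goes with the 2-methoxybenzyl group rather than with the hydrogen, though nothing available explains why the added methyl leaves the number in place.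

From the compounds shown here alone, it remains open whether an ethyl or isopropyl group on that nitrogen would be accepted as readily as methyl. Also open, going by these compounds, is how much of the low number belongs to the methoxy group itself, a question that a plain benzyl group on the same nitrogen would address.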